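From Trifluoromethyl to Nitro on a Shared Core

The source may hold more compounds than are shown below. What is called first, only, known or untested is meant among the compounds shown, and "the series" means these compounds.

Three compounds that share one core and differ in a single group on the aromatic ring have been tested in a functional assay (muscle tissue) with Cavia porcellus as the target; a higher number here means that more compound is needed for the effect, a lower number that less compound is needed. Compound 1 `COC(=O)C1=C(C)N=C(C)/C(=C(\O)OC)C1c1cccc(OC)c1`, carrying methoxy, gives 191 nM. Compound 2 `COC(=O)C1=C(C)N=C(C)/C(=C(\O)OC)C1c1cccc(O)c1`, carrying hydroxy, gives 1000 nM. Compound 3 `COC(=O)C1=C(C)N=C(C)/C(=C(\O)OC)C1c1cccc(C(F)(F)F)c1`, carrying trifluoromethyl, gives 74.1 nM, the lowest of the three numbers, so it needs the least compound for the effect.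

Compound 4 `COC(=O)C1=C(C)N=C(C)/C(=C(\O)OC)C1c1cccc([N+](=O)[O-])c1` has nitro in place of trifluoromethyl on an aromatic carbon. Within the data shown here, no measured step makes this exact swap. Three steps at the same place show how far the number can move: a 5.2-fold higher number from compound 1 to compound 2 (0.72 log units; beyond the scatter), a 2.6-fold lower number from compound 1 to compound 3 (0.41 log units; beyond the scatter) and a 13-fold lower number from compound 2 to compound 3 (1.13 log units; beyond the scatter). With no direct guide for nitro, a modest step is a more cautious expectation than a large one, and the lower direction is a tentative judgment.

The expected outcome is a 2.5-fold lower number from compound 3 to compound 4 (0.39 log units; beyond the scatter). For compound 4 the estimated value is 30 nM, with an expected range from 8 nM to 110 nM.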

Compound 4, half-maximal effective concentration: 3.98 nM
Beside the measured number, compound 4's estimate is 7.5-fold (0.88 log units) above it, and the stated range ends above it.
By their numbers in this assay, from the lowest: compound 4; then compound 3; then compound 1; then compound 2.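

In this assay, the swap to nitro brings a 19-fold lower number from compound 3 to compound 4 (1.27 log units; beyond the scatter) and shows that this place on the aromatic ring can move the number further than the first three compounds revealed. Nitro also stands well apart from the other two groups, with a 48-fold lower number from compound 1 to compound 4 (1.68 log units; beyond the scatter) and a 250-fold lower number from compound 2 to compound 4 (2.40 log units; beyond the scatter) as the largest steps in the series, and the step from trifluoromethyl alone is already larger than any step among the earlier compounds. No measurement shown here explains why nitro differs so sharply from trifluoromethyl.

From the compounds shown here alone, whether this low number belongs to nitro alone stays open, since a nitrile or a carboxylic acid at the same place could land close to compound 4 or far from it. The compounds shown also cannot tell whether nitro would keep this lead on a different core.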